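Substitution on the phenylcarbamoyl group: compound 3 to compound 4

A few compounds are considered here, and "the series" means these few. Any claim that something is new, unique, unknown or untested is made for them only; others in the source may bear on it.

In an assay on tissue (HeLa cells) for inhibition of Indoleamine 2,3-dioxygenase 1 (Homo sapiens), with a stated time of 48 h (a higher number here means a weaker inhibitor, a lower number a stronger inhibitor), compound 3 `O=C(/C(=N/O)Nc1ccc(F)c(Br)c1)C1CCN(C(=O)Nc2ccccc2)CC1` gives 54 nM, the highest of the three numbers; compound 1 `NS(=O)(=O)N1CCC(C(=O)/C(=N/O)Nc2ccc(F)c(Br)c2)CC1` gives 45 nM and compound 2 `O=C(/C(=N/O)Nc1ccc(F)c(Br)c1)C1CCN(C(=O)NCc2ccccc2)CC1` gives 28 nM, and all three sit within the scatter of one another, as the steps of a 1.2-fold higher number from compound 1 to compound 3 (0.08 log units; within the scatter) and a 1.9-fold higher number from compound 2 to compound 3 (0.29 log units; within the scatter) show. Compound 4 `Cn1cc(-c2ccc(NC(=O)N3CCC(C(=O)/C(=N/O)Nc4ccc(F)c(Br)c4)CC3)cc2)cn1` differs from compound 3 by 1-methyl-1H-pyrazol-4-yl in place of hydrogen on an aromatic carbon. For the measured compounds named here, no measured step touches this aromatic carbon; the steps recorded, a 1.6-fold lower number from compound 1 to compound 2 (0.21 log units; within the scatter) included, all concern the group on the ring amine nitrogen and none passes beyond the scatter. No change beyond the scatter is therefore expected in this assay, and the step from compound 3 to compound 4 is estimated at a 1.4-fold lower number from compound 3 to compound 4 (0.13 log units; within the scatter). For compound 4 the expected value is 40 nM, with a range from 15 nM to 110 nM.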

Compound 4, half-maximal inhibitory concentration: 15 nM
Beside the measured number, compound 4's estimate is 2.7-fold (0.43 log units) above it, and the stated range covers the measured number.
By their numbers in this assay, from the lowest: compounds 4, 2, 1 and 3 (each within the scatter of the next, the first and the last beyond it).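

In this assay the change from hydrogen to 1-methyl-1H-pyrazol-4-yl gives a 3.6-fold lower number from compound 3 to compound 4 (0.56 log units; beyond the scatter) and is the only step shown beyond the scatter. The aromatic carbon para to a large group therefore takes a group of 6 heavy atoms with a gain in inhibition, whereas the changes on the ring amine nitrogen stayed within the scatter. No measurement at hand bears on the reason for this step. Open, from the compounds shown here alone, is whether a smaller group at this carbon, such as methyl or methoxy, or a plain phenyl ring, gives a similar step. Also open, going by these compounds, is whether 1-methyl-1H-pyrazol-4-yl acts the same way on the benzylcarbamoyl group of compound 2.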